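Expecting a higher reading for compound 3

This account rests on a few compounds, and the source may have more. Where it says the series, first, only, none or still open, it means among the compounds named here.

Going by the values given here, in a physicochemical assay for lipophilicity, read by HPLC, at pH 7.4 (a lower number here means a more polar compound, a higher number a more lipophilic compound), compound 2 `CCOc1cc2oc(=O)n(CCC(=O)O)c2cc1Cl` gives 1.49 and stands lowest of the two numbers so far, under compound 1 `C[C@@H](Oc1cc2oc(=O)n(CCC(=O)O)c2cc1Cl)c1ccc(F)cn1` with 1.98 as its reading. Compound 3 `Cc1ccnc([C@@H](C)Oc2cc3oc(=O)n(CCC(=O)O)c3cc2Cl)c1` arises through one change 4-methylpyridin-2-yl in place of hydrogen on a saturated chain carbon bound to an oxygen on an aromatic ring and a saturated chain carbon on a saturated chain carbon bound to an oxygen on an aromatic ring and a saturated chain carbon. Among the compounds with values here, only one measured step bears on this: a number 0.49 log units lower from compound 1 to compound 2 (beyond the scatter) in which hydrogen replaced 5-fluoropyridin-2-yl at that place. Read in reverse, it points to a modest rise, though the entering group here is a different one. The expected step is a number 0.51 log units higher from compound 2 to compound 3 (beyond the scatter) in this assay (an increase). The estimated value for compound 3 is 2 (range 1.65 to 2.35).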

Compound 3, distribution coefficient: 2.15
The estimate for compound 3 lay 0.15 log units below the measured number; the range from low to high includes it.
By their numbers in this assay, from the lowest: compound 2; then compounds 1 and 3 (each within the scatter of the next).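

In this assay the change from hydrogen to 4-methylpyridin-2-yl gives a number 0.66 log units higher from compound 2 to compound 3 (beyond the scatter) and so repeats, with a second ring, the upward direction that 5-fluoropyridin-2-yl showed at this saturated chain carbon. Exchanging the two rings gives a number 0.17 log units higher from compound 1 to compound 3 (within the scatter) and this lies within the scatter, so this assay does not separate them. Nothing measured here accounts for either step. On these data alone, whether a plain phenyl ring would read like these two pyridinyl groups remains open. So does the reading of a chain carrying an amine at this place.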